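Swapping 2-methyl-1,3-thiazol-4-yl for 2-methyl-1,3-oxazol-4-yl

The source may hold more compounds than are shown below. What is called first, only, known or untested is meant among the compounds shown, and "the series" means these compounds.

Three compounds have been tested in an in vitro ADME assay on microsomes from liver (Rattus norvegicus) for metabolic stability; a higher number here means faster removal of the compound, a lower number slower removal:

- Compound 1 `Cc1ccc(Cn2c(=O)[nH]c3c(N)nc(C(F)(F)F)cc32)nn1`: < 11 mL.min-1.g-1 (a limit)
- Compound 2 `Cc1cc(Cn2c(=O)[nH]c3c(N)nc(C(F)(F)F)cc32)no1`: < 9 mL.min-1.g-1 (a limit)
- Compound 3 `Cc1nc(Cn2c(=O)[nH]c3c(N)nc(C(F)(F)F)cc32)cs1`: < 10 mL.min-1.g-1 (a limit)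

Compound 3 stands at < 10 mL.min-1.g-1, and this is a limit of the assay, not a number. The other two compounds also sit at limits, so the three cannot be ranked.

Compound 4 `Cc1nc(Cn2c(=O)[nH]c3c(N)nc(C(F)(F)F)cc32)co1` keeps the shared core and changes one group: 2-methyl-1,3-oxazol-4-yl in place of 2-methyl-1,3-thiazol-4-yl on a saturated chain carbon bound to an aromatic nitrogen. Here 2-methyl-1,3-oxazol-4-yl replaces 2-methyl-1,3-thiazol-4-yl on a saturated chain carbon bound to an aromatic nitrogen.

Going by the values given here, no measured step makes exactly this swap. The closest evidence comes from exchanges of other groups at the same place: a step that the two limits leave unreadable from compound 1 to compound 2, a step that the two limits leave unreadable from compound 1 to compound 3 and a step that the two limits leave unreadable from compound 2 to compound 3. None of these has a readable size, but all three compounds ended at a limit. On that basis, no step beyond the usual scatter is expected in this assay, and no direction can be given.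

The expected size is a step that the limit leaves unreadable from compound 3 to compound 4. Compound 4 is estimated at 7 mL.min-1.g-1, with an expected range from 3 mL.min-1.g-1 to 13 mL.min-1.g-1, and it may well be reported only as a limit.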

Compound 4, intrinsic clearance in microsomes: < 10 mL.min-1.g-1
Compound 4 ended at the assay's limit (the forecaster's own chance of this, stated with the estimate: 75%); the middle value is on the limit's open side.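

In this assay compound 4 gives < 10 mL.min-1.g-1, a limit of the assay and not a number. Going by these compounds alone, compound 1, compound 2 and compound 3 also sit at limits, and no step from any of them to compound 4 can be read. The compounds shown leave open how fast each one is actually removed, and whether exchanging these groups changes that at all.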